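Toward a chloropyridinyl amide from a dichlorophenyl amide

This account rests on a few compounds, and the source may have more. Where it says the series, first, only, none or still open, it means among the compounds named here.

Compound 1 `COc1ccc(C(=O)Nc2cccc(Cl)c2Cl)cc1OC1CCCC1` is the starting point. In an assay on isolated protein for inhibition of phosphodiesterase 4A (Sus scrofa) (on this read-out lower numbers stand for stronger inhibition and higher numbers for weaker inhibition), compound 1 gives only a limit, > 200000 nM, and not a number. Compound 1 therefore stands at the limit of > 200000 nM in this assay, at which 1 of the 3 values shown sits. Two related compounds give numbers: compound 2 `COc1ccc(C(=O)Nc2ccccc2Cl)cc1OC` gives 650 nM in this assay, and compound 3 `COc1ccc(C(=O)Nc2ccccc2Cl)cc1OC(C)=O` gives 70000 nM. Going by the values given here, the single measured step, a 110-fold higher number from compound 2 to compound 3 (2.03 log units; beyond the scatter), concerns a group on an oxygen on an aromatic ring and not the amide nitrogen. Compound 4 `COc1ccc(C(=O)Nc2ccncc2Cl)cc1OC1CCCC1` differs from compound 1 at the amide nitrogen: 3-chloropyridin-4-yl in place of 2,3-dichlorophenyl on an amide-type nitrogen. No measured step touches this position, so the move from compound 1 to compound 4 has no precedent among these compounds, and compound 1 itself supplies only a limit from which to start. Compound 4 is expected to give 20000 nM in this assay, with a range from 500 nM to 200000 nM. The expected step of an at least 10-fold lower number from compound 1 to compound 4 (1.00 log units; beyond the scatter) is estimated with low confidence, and a limit rather than a number remains possible for compound 4 as well.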

Compound 4, half-maximal inhibitory concentration: 16 nM
Compound 4: the middle estimate sits 1300-fold (3.10 log units) above what was measured; the measured number lies below the stated range.
By their numbers in this assay, from the lowest: compound 4; then compound 2; then compound 3. At a limit, above all of these: compound 1.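

In this assay, the amide nitrogen proves to be a highly sensitive position: 3-chloropyridin-4-yl in place of 2,3-dichlorophenyl gives an at least 12000-fold lower number from compound 1 to compound 4 (4.09 log units; beyond the scatter). Going by these compounds alone, the earlier compounds showed a large change only for a group on an oxygen on an aromatic ring, so this is the first sign that the group on the amide-type nitrogen can also decide the read-out. Compound 1 gives > 200000 nM, which is a limit and not a number, so the step fixes only a smallest size and not a true one.

The change brings in a ring nitrogen and removes one chlorine at once, and the compounds shown do not separate these two parts. They also leave open how an amine or a carboxylic acid on the 3-chloropyridin-4-yl group would read in this assay.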